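Notes on a small series: acetyl against dimethylamino

The source may report more compounds than this note shows. Statements on the series, on what has been measured and on what is new or still open speak of the compounds shown alone.

Measured so far:
compound 1: `COc1cc(C)cc(-c2c(-c3ccnc(-c4ccc(C(C)=O)cc4)c3)cnn2CC#N)c1`, 96%
compound 2: `COc1cc(C)cc(-c2nn(CC#N)cc2-c2ccc(-c3cccc(C(C)=O)c3)nc2)c1`, 96%
compound 3: `Cc1cc(O)cc(-c2nn(CC#N)cc2-c2ccnc(-c3ccc(N(C)C)cc3)c2)c1`, 97%

All three values come from a functional assay on CCRF-CEM cells (Homo sapiens) for cytotoxicity, read by sulforhodamine B assay, with a stated time of 48 h, tested at 0.001 uM; on this read-out lower numbers stand for a stronger effect and higher numbers for a weaker effect at the one concentration tested. Compound 1 stands level with compound 2 at the digits shown, and compound 3 lies within the scatter of both, so the three numbers cannot be told apart; at this concentration none of them shows more than a faint effect.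

Compound 4 is `COc1cc(C)cc(-c2c(-c3ccnc(-c4ccc(N(C)C)cc4)c3)cnn2CC#N)c1`. It differs from compound 1 in one place: dimethylamino in place of acetyl on an aromatic carbon. Compound 3 also carries the dimethylamino group, but it differs from compound 1 elsewhere as well, so only its value can be noted. On these numbers, the step from compound 1 to compound 4 is expected to be none beyond the scatter, no change at the digits printed from compound 1 to compound 4 (within the scatter). Compound 4 is therefore estimated at 96%, between 88% and 100%.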

Compound 4, a percentage reported as activity, at one concentration (the size of the read-out at that concentration, not a potency): 95%
Compound 4: the middle estimate sits 1 percentage points above what was measured, within the range that was stated.
By their numbers in this assay, from the lowest: compounds 4, 1, 2 and 3 (each within the scatter of the next).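

In this assay, for the compounds shown here, the one single-place comparison gives a number 1 percentage points lower from compound 1 to compound 4 (within the scatter) and so stays within the scatter. At this place on the ring, dimethylamino in place of acetyl therefore leaves the read-out unchanged at this single concentration, which compounds 2 and 3, each differing from compound 1 in more than one place, could not show. No available evidence bears on this result.

Still open, as far as these compounds go, is what a carboxylic acid or a longer alkyl chain at this place would give in this assay. Any effect of this change at higher concentrations also remains open.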